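A few compounds are considered here, and "the series" means these few. Any claim that something is new, unique, unknown or untested is made for them only; others in the source may bear on it.

Compound 1 `CC1CCN(S(=O)(=O)N2CCN(CC(=O)Nc3ccc(Cl)cc3)CC2)CC1` was tested in an assay on HEK293 cells for activation of potassium channel subfamily T member 1 (Homo sapiens), read by thallium flux (a higher number here means that more compound is needed for the effect, a lower number that less compound is needed), where it gives only a limit, > 10000 nM. Compound 2 `COc1ccc(Cl)cc1NC(=O)CN1CCN(S(=O)(=O)N2CCN(C(=O)N3CCCCCC3)CC2)CC1` likewise gives only a limit in this assay, > 10000 nM. Among the measured compounds shown here, both results therefore sit at the limit of > 10000 nM in this assay, at which 2 of the 2 values shown sit, so no step between measured compounds can be read, and the size of a change cannot be learned from them. Compound 3 `CC1CCN(S(=O)(=O)N2CCN(CC(=O)Nc3cc(Cl)ccc3F)CC2)CC1` differs from compound 1 by 5-chloro-2-fluorophenyl in place of 4-chlorophenyl on an amide-type nitrogen. With nothing measured to lean on, the step of a number no higher from compound 1 to compound 3 (the limit leaves the size open) is expected to be small, within the usual scatter. Compound 3 is thus estimated at 10000 nM, with a range from 2500 nM to 40000 nM, and a limit remains the likelier outcome.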

Compound 3, half-maximal effective concentration: 3800 nM
Compound 3: middle estimate off by 2.6-fold (0.42 log units), on the high side, within the range that was stated.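

The aryl group on the amide-type nitrogen matters in this assay: with the rest of the molecule unchanged, 5-chloro-2-fluorophenyl in place of 4-chlorophenyl gives an at least 2.6-fold lower number from compound 1 to compound 3 (0.42 log units; beyond the scatter). Compound 3 thus yields an actual number, showing that this series can register in the assay. The true size of the step stays unknown because the value for compound 1 is only a limit: the limit of > 10000 nM in this assay, at which 2 of the 3 values shown sit.

As far as these compounds go, whether the added fluorine or the changed place of the chlorine carries the step remains open. So does the outcome with a plain phenyl or a 2-fluorophenyl group.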